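The source may hold more compounds than are shown below. What is called first, only, known or untested is meant among the compounds shown, and "the series" means these compounds.

Measured in an ADME assay for permeability, using PAMPA, at pH 7.4; a higher number here means that the compound crosses the layer faster, a lower number that the compound crosses the layer more slowly:
- compound 1 `Cc1[nH]c2ccccc2c(=O)c1Cc1ccccc1`: 102 10^-6 cm/s
- compound 2 `COc1cccc2c(=O)c(Cc3ccccc3)c(C)[nH]c12`: 125 10^-6 cm/s
- compound 3 `Cc1[nH]c2c(Cl)cccc2c(=O)c1Cc1ccccc1`: 412 10^-6 cm/s

Compound 1 sits in the lower pair of these numbers. Among the measured compounds shown here, its nearest neighbour shows a 1.2-fold higher number from compound 1 to compound 2 (0.09 log units; within the scatter), while the only measured compound clear of it shows a 4.0-fold higher number from compound 1 to compound 3 (0.61 log units; beyond the scatter).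

Compound 4 `COc1cccc2[nH]c(C)c(Cc3ccccc3)c(=O)c12` has not yet been measured. It is built from compound 1 by one change, methoxy in place of hydrogen on an aromatic carbon. This carbon is ortho to a fused ring and meta to a fused ring.

For the measured compounds named here, the closest precedent is the same swap made on a different aromatic carbon of the shared core, which gave a 1.2-fold higher number from compound 1 to compound 2 (0.09 log units; within the scatter). The chloro compound bears on it less directly. It shows that a single substituent on this ring can matter in this assay, with a 3.3-fold higher number from compound 2 to compound 3 (0.52 log units; beyond the scatter) between the two groups.

Going by the values given here, no measurement yet covers a methoxy on the carbon used in compound 4, so some uncertainty remains in either direction. On the precedent of a 1.2-fold higher number from compound 1 to compound 2 (0.09 log units; within the scatter), no change beyond the scatter is expected, and the estimated step is a 1.1-fold higher number from compound 1 to compound 4 (0.05 log units; within the scatter). Compound 4 is estimated at 115 10^-6 cm/s, with an expected range from 55 10^-6 cm/s to 240 10^-6 cm/s.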

Compound 4, apparent permeability: 158 10^-6 cm/s
Estimate against measurement, compound 4: 1.4-fold (0.14 log units) below; the measured number falls inside the stated range.
By their numbers in this assay, from the lowest: compounds 1, 2 and 4 (each within the scatter of the next); then compound 3.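

In this assay, methoxy in place of hydrogen on this aromatic carbon, ortho to a fused ring and meta to a fused ring, stays within the scatter (a 1.5-fold higher number from compound 1 to compound 4 (0.19 log units; within the scatter)), so this carbon now has a reading of its own rather than one borrowed from another carbon of the shared core. Alongside the earlier step with the same swap (a 1.2-fold higher number from compound 1 to compound 2 (0.09 log units; within the scatter)), methoxy has now been read on two aromatic carbons, and neither step lies beyond the scatter, which leaves the chloro of compound 3 as the only group shown that moves the number clear of compound 1 (a 4.0-fold higher number from compound 1 to compound 3 (0.61 log units; beyond the scatter)). Nothing available explains why the methoxy steps stay within the scatter or why the chloro step does not.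

The compounds shown leave open whether chloro on the carbon used in compound 4 would give a step as large as the one seen on the carbon used in compound 3. They also leave open whether a different group on this carbon, such as an amine, a carboxylic acid or a longer chain than methoxy, would stay within the scatter of compound 1 as methoxy does.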